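This account rests on a few compounds, and the source may have more. Where it says the series, first, only, none or still open, it means among the compounds named here.

Of the compounds shown here, three have been measured in an ADME assay for pharmacokinetics, read by LC-MS, in phosphate buffer, with a stated time of 72 h, at pH 7.4, tested at 250 uM; on this read-out higher numbers stand for a longer-lived compound and lower numbers for a shorter-lived compound.
Compound 1 `C=CC(=O)Nc1cc(C(F)(F)F)cc(C(F)(F)F)c1` gives 0.8 h.
Compound 2 `C=CS(=O)(=O)c1cc(C(F)(F)F)cc(C(F)(F)F)c1` sits at < 0.017 h, a limit of the method (the limit of < 0.017 h in this assay, at which 1 of the 3 values shown sits).
Compound 3 `N#Cc1cc(C(F)(F)F)cc(C(F)(F)F)c1` sits at > 50 h, likewise a limit (the limit of > 50 h in this assay, at which 1 of the 3 values shown sits).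

Compound 3 therefore stands at the top of the numbers shown: an at least 62-fold higher number from compound 1 to compound 3 (1.79 log units; beyond the scatter) and an at least 2900-fold higher number from compound 2 to compound 3 (3.46 log units; beyond the scatter), both large, while an at least 47-fold lower number from compound 1 to compound 2 (1.67 log units; beyond the scatter). Compound 4 `FC(F)(F)c1cc(S)cc(C(F)(F)F)c1` differs from compound 3 by sulfanyl in place of cyano on an aromatic carbon. Going by the values given here, no measured step removes the cyano group or introduces a sulfanyl group; the measured steps concern only the vinyl-bearing groups of compounds 1 and 2, so they bear on this change only in showing where compound 3 stands. A moderate downward step in this assay is expected, with wide uncertainty: an at least 2.5-fold lower number from compound 3 to compound 4 (0.39 log units; beyond the scatter). Compound 4 is estimated at 20 h, in a range from 3 h to 60 h.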

Compound 4, half-life: > 50 h
Compound 4: no number, only a limit; the forecaster's own chance of this, stated with the estimate: 35%; middle value at least 2.5-fold (0.39 log units) away from the limit.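

In this assay compound 4 sits at > 50 h, a limit and not a number. Sulfanyl on this aromatic carbon, meta to two trifluoromethyl groups, thus reaches the same upper limit as cyano in compound 3, and the step between these two compounds cannot be read: the limit of > 50 h in this assay, at which 2 of the 4 values shown sit. Like cyano, sulfanyl stands well clear of both vinyl-bearing groups, with an at least 62-fold higher number from compound 1 to compound 4 (1.79 log units; beyond the scatter) and an at least 2900-fold higher number from compound 2 to compound 4 (3.46 log units; beyond the scatter).

On these data alone, how far compound 3 and compound 4 lie beyond this limit stays open. So does whether an amine or a carboxylic acid in this place would also reach it.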